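Piperidine-linked piperazines as B1 bradykinin antagonists

The source may report more compounds than this note shows. Statements on the series, on what has been measured and on what is new or still open speak of the compounds shown alone.

Measured compounds:
Compound 1 `COc1cc(C)c(S(=O)(=O)N(C)CCOCC(=O)N2CCC(N3CCN(C(C)C)CC3)CC2)c(C)c1` gives 8.5 in a functional assay on Umbilical vein for antagonist activity at B1 bradykinin receptor (Homo sapiens), using Schild analysis, with a stated time of 30 min; on this read-out higher numbers stand for higher potency (the scale is a negative logarithm) and lower numbers for lower potency.
Compound 2 `COc1cc(C)c(S(=O)(=O)N(C)CCOCC(=O)N2CCN([C@@H]3CN4CCC3CC4)CC2)c(C)c1` gives 8.1 in this assay.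
Compound 3 `Cc1c(Cl)ccc(S(=O)(=O)N(C)CCCCC(=O)N(C)Cc2ccc(C3=NCCN3)cc2)c1Cl` gives 7.3 in this assay.

Compound 1 stands highest of the three, its nearest neighbour being compound 2, and compound 3 lying furthest away; both gaps exceed the usual scatter. Compound 4 `COc1cc(C)c(S(=O)(=O)N(C)CCOCC(=O)N2CCC(CN3CCN(C)CC3)CC2)c(C)c1` keeps the core of compound 1 and differs only by (4-methylpiperazin-1-yl)methyl in place of 4-isopropylpiperazin-1-yl on a saturated ring carbon. Among the compounds with values here, no measured pair shows the effect of such a change, so the expectation rests on compound 1 alone. A modest loss is expected, with the step from compound 1 to compound 4 estimated at a number 0.30 log units lower from compound 1 to compound 4 (within the scatter). Compound 4 is therefore estimated at 8.2 in this assay, with a range from 7.5 to 8.9.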

Compound 4, negative logarithm of the antagonist equilibrium constant: 8.1
The estimate for compound 4 lay 0.10 log units above the measured number, within the range that was stated.
By their numbers in this assay, from the lowest: compound 3; then compounds 2 and 4 (each within the scatter of the next); then compound 1.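

Replacing 4-isopropylpiperazin-1-yl with (4-methylpiperazin-1-yl)methyl on this saturated ring carbon gives a number 0.40 log units lower from compound 1 to compound 4 (beyond the scatter) in this assay. Within the data shown here, this is the first direct reading at this position, and it shows that the read-out responds to a swap between two groups that both hold a piperazine ring and have the same donor and acceptor counts. Nothing measured here explains the step. The swap alters both the attachment and the piperazine's alkyl group, so 4-methylpiperazin-1-yl and (4-isopropylpiperazin-1-yl)methyl would be needed to separate these two parts.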